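A Hydroxyphenyl Swap Carried Over to a Second Core

The compounds below may be only part of what the source reports. "The series", "measured", "known", "first", "only" and "open" are said of these compounds alone.

Compound 1 `O=C1OC[C@H](Cc2cccc(F)c2)[C@H]1Cc1ccc(Cl)c(Cl)c1`: 14000 nM
Compound 2 `O=C1OC[C@H](Cc2ccc(O)cc2)[C@H]1Cc1ccc(Cl)c(Cl)c1`: 37000 nM
Compound 3 `Fc1cccc(C[C@H]2COC[C@@H]2Cc2ccc(Cl)c(Cl)c2)c1`: 20000 nM

All three compounds were tested in a functional assay on HL-60 cells (Homo sapiens) for cytotoxicity, read by WST assay, with a stated time of 48 h; on this read-out higher numbers stand for an effect only at larger amounts of compound and lower numbers for an effect already at smaller amounts. Compound 1 and compound 2 share the core of compound 1 and differ in one place only: 4-hydroxyphenyl in place of 3-fluorophenyl on a saturated chain carbon bound to a saturated ring carbon. That single change produced a 2.6-fold higher number from compound 1 to compound 2 (0.42 log units; beyond the scatter), so the hydroxyphenyl compound needs a somewhat larger amount for the same effect on these cells.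

Compound 3 carries the same 3-fluorophenyl group as compound 1 but sits on a different core; the difference between the two cores is not broken down here. The values of compound 3 and compound 1 lie within the usual scatter of each other, and so do those of compound 3 and compound 2, so no ordering among them can be read from this assay.

Compound 4 `Oc1ccc(C[C@H]2COC[C@@H]2Cc2ccc(Cl)c(Cl)c2)cc1` has not been measured. It differs from compound 3 by 4-hydroxyphenyl in place of 3-fluorophenyl on a saturated chain carbon bound to a saturated ring carbon, which is the same change, at the same place, that turned compound 1 into compound 2. Because that earlier change gave a 2.6-fold higher number from compound 1 to compound 2 (0.42 log units; beyond the scatter), a step of similar size is expected here, namely a 2.5-fold higher number from compound 3 to compound 4 (0.40 log units; beyond the scatter). This rests on a single earlier instance on another core, so the expectation is loose. Compound 4 is therefore estimated at 50000 nM, with a likely range from 25000 nM to 100000 nM.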

Compound 4, half-maximal effective concentration: 31000 nM
The estimate for compound 4 lay 1.6-fold (0.21 log units) above the measured number; low and high end bracket the measured number.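

In this assay, putting 4-hydroxyphenyl in place of 3-fluorophenyl on the core of compound 3 gave a 1.6-fold higher number from compound 3 to compound 4 (0.19 log units; within the scatter), so this step alone cannot be told apart from ordinary repeat-to-repeat variation. Even so, the change carries over in the sense that its size on the two cores cannot be told apart, and the data give no sign that the core of compound 3 responds differently from the core of compound 1: the same change on two cores in this assay, a 2.6-fold higher number (0.42 log units; beyond the scatter) from compound 1 to compound 2 and a 1.6-fold higher number (0.19 log units; within the scatter) from compound 3 to compound 4, 1.7-fold (0.23 log units) apart, within the scatter of two such steps. For the compounds shown here, this does not show that the change acts identically on both cores, nor that it truly raises the number on the core of compound 3, since the comparison rests on only two pairs and only the step on the core of compound 1 stands clear of the scatter.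

The swap replaces one substituted phenyl group with another, so the compounds shown cannot say how much of the step belongs to losing the fluorine and how much to gaining the hydroxyl. Also open, as far as these compounds go, is how other groups at this place would behave on either core, such as a plain phenyl, a methoxyphenyl, or a phenyl carrying an amine or a carboxylic acid.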